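The compounds below may be only part of what the source reports. "The series", "measured", "known", "first", "only" and "open" are said of these compounds alone.

Measured compounds: compound 1 `CC[C@@H](Nc1c(C#N)c(-c2ccc(-c3ccc(OC)cc3)cc2)nc2cnccc12)C(N)=O`, compound 2 `CC[C@@H](Nc1c(C#N)c(-c2ccc(-c3cccc(CO)c3)cc2)nc2cnccc12)C(N)=O`, compound 3 `CC[C@@H](Nc1c(C#N)c(-c2ccc(-c3ccccc3COC)cc2)nc2cnccc12)C(N)=O`.

In a physicochemical assay for lipophilicity, read by HPLC, at pH 7.5 (a higher number here means a more lipophilic compound, a lower number a more polar compound), compound 1 gives 2.7, compound 2 gives 2 and compound 3 gives 2.6. Compound 3 stands second highest of the three numbers: its nearest neighbour is compound 1, with a number 0.10 log units lower from compound 1 to compound 3 (within the scatter), and the furthest is compound 2, with a number 0.60 log units higher from compound 2 to compound 3 (beyond the scatter). Compound 4 `CC[C@@H](Nc1c(C#N)c(-c2ccc(-c3ccccc3Cl)cc2)nc2cnccc12)C(N)=O` differs from compound 3 by chloro in place of methoxymethyl on an aromatic carbon. Among the compounds with values here, no measured step exchanges methoxymethyl for chloro, so the expectation rests only on how much changes on the outer phenyl have moved the read-out: a number 0.70 log units lower from compound 1 to compound 2 (beyond the scatter) and a number 0.60 log units higher from compound 2 to compound 3 (beyond the scatter) were modest, while a number 0.10 log units lower from compound 1 to compound 3 (within the scatter) stayed within the scatter. A modest rise in this assay is expected, a number 0.70 log units higher from compound 3 to compound 4 (beyond the scatter). Compound 4 is therefore estimated at 3.3, within 2.8 to 3.8.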

Compound 4, distribution coefficient: 2.9
The estimate for compound 4 lay 0.40 log units above the measured number; the measured number falls inside the stated range.
By their numbers in this assay, from the lowest: compound 2; then compounds 3, 1 and 4 (each within the scatter of the next).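

The exchange of methoxymethyl for chloro, on an aromatic carbon ortho to a large group, gives a number 0.30 log units higher from compound 3 to compound 4 (within the scatter) in this assay and is therefore not resolved by this read-out, despite the change from three heavy atoms to one. The 2-chlorophenyl group gives a number 0.20 log units higher from compound 1 to compound 4 (within the scatter) against 4-methoxyphenyl and a number 0.90 log units higher from compound 2 to compound 4 (beyond the scatter) against 3-(hydroxymethyl)phenyl, so only compound 2 stands apart among the four. No measurement at hand accounts for these steps.

From the compounds shown here alone, whether an amine or a carboxylic acid at this carbon would separate from compound 4 as compound 2 does remains open. So does the reading for chloro on other carbons of this ring.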